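This account rests on a few compounds, and the source may have more. Where it says the series, first, only, none or still open, it means among the compounds named here.

Measured so far:
compound 1 `Fc1ccc(-c2ccc3c(NCCCNCc4ccco4)ccnc3c2)cc1`: 32000 nM
compound 2 `CCC(CC)c1ccc2c(NCCCNCc3cc(F)ccc3OC)ccnc2c1`: 4200 nM
compound 3 `CCC(CC)c1ccc2c(NCCCNCc3ccco3)ccnc2c1`: 4200 nM

All three values come from a physicochemical assay for solubility, with a stated time of 18 h, at pH 7.4; a lower number here means a less soluble compound, a higher number a more soluble compound. Compound 2 and compound 3 differ in one place, (5-fluoro-2-methoxyphenyl in place of furan-2-yl on a saturated chain carbon bound to an amine nitrogen), and that difference gives no change at the digits printed from compound 2 to compound 3 (within the scatter). Compound 3 and compound 1 differ in one place as well, (4-fluorophenyl in place of pentan-3-yl on an aromatic carbon), and here the step is larger: a 7.6-fold higher number from compound 3 to compound 1 (0.88 log units; beyond the scatter).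

Compound 4 `COc1ccc(F)cc1CNCCCNc1ccnc2cc(-c3ccc(F)cc3)ccc12` has not yet been measured in this assay. Its relation to compound 2 is the same change that separates compound 3 from compound 1: 4-fluorophenyl in place of pentan-3-yl on an aromatic carbon. The two cores on which the change is made differ only as described above for compound 2 against compound 3, and that difference made no change within the scatter of this assay.

With one measured example of the change, the expectation for compound 4 rests on the step from compound 3 to compound 1 being repeated on the core of compound 2. For the measured compounds named here, the step from compound 2 to compound 4 in this assay is therefore expected to be a 7.1-fold higher number from compound 2 to compound 4 (0.85 log units; beyond the scatter), because a 7.6-fold higher number from compound 3 to compound 1 (0.88 log units; beyond the scatter) is the only measured precedent. Going by the values given here, compound 4 is estimated at 30000 nM in this assay, with a range from 12000 nM to 75000 nM, the range being wide because no change at the digits printed from compound 2 to compound 3 (within the scatter) shows only that the two cores behave alike, not that the change transfers exactly.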

Compound 4, solubility: 32000 nM
Estimate against measurement, compound 4: 1.1-fold (0.03 log units) below, and the stated range covers the measured number.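

In this assay, the change to 4-fluorophenyl in place of pentan-3-yl carries across the two cores shown: it gives a 7.6-fold higher number from compound 2 to compound 4 (0.88 log units; beyond the scatter), and the same size of step as a 7.6-fold higher number from compound 3 to compound 1 (0.88 log units; beyond the scatter) on the other core. The step at the second site also repeats, with no change at the digits printed from compound 1 to compound 4 (within the scatter) alongside no change at the digits printed from compound 2 to compound 3 (within the scatter), so the four compounds form a closed square in which the two changes read as independent of each other, and none of the four goes against this. This shows transfer between two closely matched cores in a single assay and for a single pair of groups, so it does not establish a general rule for the series, and no measurement shown here accounts for the size of the step.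

The compounds shown leave open whether the same step appears with other groups on that aromatic carbon, such as unsubstituted phenyl, a morpholine or a carboxylic acid. On these data alone, it is also open whether the independence of the two sites survives when furan-2-yl and 5-fluoro-2-methoxyphenyl give way to something less alike in form, such as a basic amine or a longer alkyl chain.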